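Notes on the step from compound 2 to compound 3

The source may hold more compounds than are shown below. What is called first, only, known or untested is meant among the compounds shown, and "the series" means these compounds.

Compound 1 (`C=C[C@@](C)(/C=C/c1ccc(Nc2ccc(OC)cc2)cc1)CCC=C(C)C`) gives > 36600 nM in an ADME assay on BJ cells (Homo sapiens) for cytotoxicity, with a stated time of 72 h (on this read-out higher numbers stand for an effect only at larger amounts of compound and lower numbers for an effect already at smaller amounts), as a limit of the assay, not a number. Compound 2 (`C=C[C@@](C)(/C=C/c1ccc(Nc2ccc(Cl)cc2)cc1)CCC=C(C)C`) gives > 36600 nM as a limit too, so where it stands is known only as a limit and not as a value. The evidence so far amounts to the limit of > 36600 nM in this assay, at which 2 of the 2 values shown sit, and no more.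

Compound 3 (`C=C[C@@](C)(/C=C/c1ccc(-c2ccc(F)cc2)cc1)CCC=C(C)C`) brings a larger change than the one already measured, with 4-fluorophenyl in place of (4-chlorophenyl)amino on an aromatic carbon (para to a large group).

Within the data shown here, the only measured step is a step that the two limits leave unreadable from compound 1 to compound 2 for chloro in place of methoxy on an aromatic carbon, and it offers no size to carry over. On that basis no step beyond the scatter is expected in this assay and no direction can be named. The expected move is a step that the limit leaves unreadable from compound 2 to compound 3 and it remains an estimate. Compound 3 is estimated at 40000 nM (expected range 15000 nM to 80000 nM), quite possibly reported as a limit again.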

Compound 3, half-maximal effective concentration: > 36600 nM
Compound 3 ended at the assay's limit; the forecaster's own chance of this, stated with the estimate: 70%; the middle value does not contradict the limit.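

In this assay compound 3 gives > 36600 nM, a limit of the assay and not a number. Among these compounds, no step from compound 1 or compound 2 to compound 3 can be read. The compounds shown leave open whether any of these changes shifts the read-out at all, and the evidence stops at: the limit of > 36600 nM in this assay, at which 3 of the 3 values shown sit.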